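Adding an isopropyl group to the phenyl of compound 1

A few compounds are considered here, and "the series" means these few. Any claim that something is new, unique, unknown or untested is made for them only; others in the source may bear on it.

Compound 1 `COc1ccc(Nc2nc(SCc3cn(Cc4ccccc4Cl)nn3)nc(-c3ccccc3)c2C#N)cc1` gives the lowest number of the three in a functional assay on B16-F10 cells (Mus musculus) for inhibition, read by MTT assay, with a stated time of 72 h (on this read-out higher numbers stand for weaker inhibition and lower numbers for stronger inhibition), at 3990 nM. Compound 2 `N#Cc1c(Nc2ccccc2Cl)nc(SCc2cn(Cc3ccccc3Cl)nn2)nc1-c1ccccc1` gives 8350 nM and compound 3 `N#Cc1c(Nc2ccccc2)nc(SCc2cn(Cc3ccccc3Cl)nn2)nc1-c1ccccc1` gives 28300 nM; the steps of a 2.1-fold higher number from compound 1 to compound 2 (0.32 log units; beyond the scatter), a 7.1-fold higher number from compound 1 to compound 3 (0.85 log units; beyond the scatter) and a 3.4-fold higher number from compound 2 to compound 3 (0.53 log units; beyond the scatter) all concern the aryl group on the amine nitrogen. Compound 4 `COc1ccc(Nc2nc(SCc3cn(Cc4ccccc4Cl)nn3)nc(-c3ccc(C(C)C)cc3)c2C#N)cc1` differs from compound 1 elsewhere: isopropyl in place of hydrogen on an aromatic carbon. Within the data shown here, no measured step touches this phenyl ring, so the data give no direction for that change. With nothing to lean on, compound 4 is expected to move only by a 1.1-fold lower number from compound 1 to compound 4 (0.06 log units; within the scatter), well within the scatter. The estimate for compound 4 in this assay is 3500 nM, with a wide range from 1000 nM to 12000 nM.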

Compound 4, half-maximal inhibitory concentration: 2690 nM
Estimate against measurement, compound 4: 1.3-fold (0.11 log units) above; the range from low to high includes it.
By their numbers in this assay, from the lowest: compounds 4 and 1 (each within the scatter of the next); then compound 2; then compound 3.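

In this assay, phenyl to 4-isopropylphenyl gives a 1.5-fold lower number from compound 1 to compound 4 (0.17 log units; within the scatter), so compound 1 and compound 4 cannot be told apart. Among these compounds, this is the first measured step on this ring, whereas all the earlier steps lay on the aryl group on the amine nitrogen, and it shows that the ring can carry isopropyl para to a large group without a step beyond the scatter. No measurement at hand offers an explanation for this result.

As far as these compounds go, whether an amine, a carboxylic acid or a longer chain at this position would also stay within the scatter remains open. So does whether isopropyl would behave alike with the amine aryl groups of compound 2 and compound 3.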